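The source may hold more compounds than are shown below. What is called first, only, known or untested is meant among the compounds shown, and "the series" means these compounds.

Of the compounds shown here, three built on a shared core have been measured in a functional assay on cells for negative allosteric modulation of metabotropic glutamate receptor 5 (Homo sapiens), read by fluorescence and calcium flux, with a stated time of 20 min; on this read-out lower numbers stand for stronger inhibition and higher numbers for weaker inhibition. Compound 1 `O=S(=O)(c1cc(Cl)cc(Cl)c1)c1cnc2cc(F)ccc2c1-c1cccc(F)c1` gives 35 nM, compound 2 `O=S(=O)(c1cc(Cl)cc(Cl)c1)c1cnc2cc(F)ccc2c1-c1ccc(F)cc1` gives 25 nM, and compound 3 `O=S(=O)(c1ccc(F)c(Cl)c1)c1cnc2cc(F)ccc2c1-c1ccc(Cl)cc1` gives 27 nM. Within the data shown here, the one single-point change among them, a 1.4-fold lower number from compound 1 to compound 2 (0.15 log units; within the scatter), lies within the scatter. Compound 3 stands close to both of the others: its nearest neighbour on the numbers is compound 2 and its furthest is compound 1, and both gaps lie within the scatter. Compound 4 `O=S(=O)(c1cc(Cl)cc(Cl)c1)c1cnc2cc(F)ccc2c1-c1ccc(Cl)cc1` arises from compound 3 by 3,5-dichlorophenyl in place of 3-chloro-4-fluorophenyl on a sulfonyl sulfur. Among the measured compounds shown here, no measured step concerns the group on the sulfonyl sulfur, and nothing in the numbers gathered so far points to a shift beyond the scatter, so the step of a 1.0-fold higher number from compound 3 to compound 4 (0.02 log units; within the scatter) is expected to be small. Compound 4 is thus estimated to give about 28 nM, in the range from 14 nM to 56 nM.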

Compound 4, half-maximal inhibitory concentration: 94 nM
The estimate for compound 4 lay 3.4-fold (0.53 log units) below the measured number; the whole stated range lies below it.
By their numbers in this assay, from the lowest: compounds 2, 3 and 1 (each within the scatter of the next); then compound 4.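

The group on the sulfonyl sulfur can move the number: 3,5-dichlorophenyl in place of 3-chloro-4-fluorophenyl gives a 3.5-fold higher number from compound 3 to compound 4 (0.54 log units; beyond the scatter) on this change alone, unlike the earlier step within the scatter. With 3,5-dichlorophenyl held on the sulfonyl sulfur, chloro in place of fluoro gives a 3.8-fold higher number from compound 2 to compound 4 (0.58 log units; beyond the scatter) and 4-chlorophenyl in place of 3-fluorophenyl gives a 2.7-fold higher number from compound 1 to compound 4 (0.43 log units; beyond the scatter) as further steps beyond the scatter. No evidence bearing on the cause of these shifts is available. The compounds shown leave open how an amine or a carboxylic acid would fare on the sulfonyl sulfur in place of these halogenated phenyl groups.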